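The source may report more compounds than this note shows. Statements on the series, on what has been measured and on what is new or still open speak of the compounds shown alone.

Measured in a functional assay on MOLT-4 cells (Homo sapiens) for inhibition, read by MTT assay, with a stated time of 48 h; on this read-out higher numbers stand for weaker inhibition and lower numbers for stronger inhibition:

compound 1 `CCOC(=O)C(=O)CC(=O)/C=C/c1cn(CCC(C)C)c2ccccc12`: "not determined" (no result reported)
compound 2 `C=C(C)Cn1cc(/C=C/C(=O)CC(=O)C(=O)OCC)c2ccccc21`: "not determined" (no result reported)
compound 3 `CC(C)CCn1cc(/C=C/C(=O)CC(=O)C(=O)O)c2ccccc21`: 20000 nM

Going by the values given here, compound 3 holds the only number, and compound 1 and compound 2 offer no result to compare it with. Compound 4 `C=C(C)Cn1cc(/C=C/C(=O)CC(=O)C(=O)O)c2ccccc21` is still to be measured. Relative to compound 3 it carries 1-methylethenyl in place of isobutyl on a saturated chain carbon bound to an aromatic nitrogen, that is, 1-methylethenyl in place of isobutyl on a saturated chain carbon bound to an aromatic nitrogen. Cut one bond further out, the same difference reads isopentyl to 2-methylprop-2-en-1-yl. Among the compounds with values here, no measured step shows what such a change does in this assay, so the expectation rests on compound 3 at 20000 nM alone. No step beyond the usual scatter is expected, and no direction is favoured. The expected outcome is a 1.1-fold lower number from compound 3 to compound 4 (0.05 log units; within the scatter), an estimated step that stays small. For compound 4 the estimated value is 18000 nM, with an expected range of 7000 nM to 45000 nM.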

Compound 4, half-maximal inhibitory concentration: 40000 nM
Beside the measured number, compound 4's estimate is 2.2-fold (0.35 log units) below it; the measured number falls inside the stated range.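

In this assay the series now has its first readable step at this place, on a saturated chain carbon bound to an aromatic nitrogen: a 2.0-fold higher number from compound 3 to compound 4 (0.30 log units; within the scatter) for the exchange of isobutyl for 1-methylethenyl. The step shows that this one exchange, which brings in a double bond outside the aromatic rings and leaves one carbon fewer, gives a result that cannot be told apart from the isobutyl compound in this read-out. Nothing available bears on why the two side chains read alike.

From the compounds shown here alone, whether a longer chain, a benzyl group or a chain ending in an amine at this place would give a step beyond the scatter remains open. With no result for the two ethyl esters, the carboxylic acid and its ester cannot be compared.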